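A few compounds are considered here, and "the series" means these few. Any claim that something is new, unique, unknown or untested is made for them only; others in the source may bear on it.

Compound 1 `O=C(CCC(F)(F)C(F)(F)C(F)(F)C(F)(F)F)NCCCCCCCCCN[C@@H]1[C@H](O)[C@@H](O)[C@H](O)[C@H]2COC(=O)N21`: > 100000 nM (a limit)
Compound 2 `O=C(CCC(F)(F)C(F)(F)C(F)(F)C(F)(F)C(F)(F)C(F)(F)F)NCCCCCCCCCN[C@@H]1[C@H](O)[C@@H](O)[C@H](O)[C@H]2COC(=O)N21`: 11000 nM

Both compounds were tested in a functional assay on T47D cells (Homo sapiens) for inhibition, read by sulforhodamine B assay, with a stated time of 48 h; on this read-out higher numbers stand for weaker inhibition of growth and lower numbers for stronger inhibition of growth. Compound 1 has no number on this read-out, only a limit: the limit of > 100000 nM in this assay, at which 1 of the 2 values shown sits. Compound 3 `O=C(CCC(F)(F)C(F)(F)C(F)(F)C(F)(F)F)NCCCCCCCCCN[C@@H]1[C@H](O)[C@@H](O)[C@@H](O)[C@H]2COC(=O)N21` keeps the chain of compound 1 and differs from it only in the shared core: the two compounds have the same atoms and bonds and differ only in configuration as drawn: 1 of 5 stereo elements differ; a stereocentre at a saturated ring carbon is drawn R in compound 1 and S in compound 3. Within the data shown here, the one measured step, an at least 9.0-fold lower number from compound 1 to compound 2 (0.95 log units; beyond the scatter), changes the fluorinated chain and not a stereocentre, so it bears only indirectly, showing that a number can be reached from this limit. Among the measured compounds shown here, no measured step gives the size of a change in configuration. A shift beyond the scatter is therefore not expected in this assay, although a lower number remains possible. The expected step is an at least 1.1-fold lower number from compound 1 to compound 3 (0.04 log units; that floor lies within the scatter). For compound 3 the estimate is 90000 nM, with an expected range of 25000 nM to 200000 nM.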

Compound 3, concentration for 50% growth inhibition: 96000 nM
Compound 3: middle estimate off by 1.1-fold (0.03 log units), on the low side, within the range that was stated.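

Among these compounds, the change of this saturated ring carbon from R to S gives the first measured step for configuration: an at least 1.0-fold lower number from compound 1 to compound 3 (0.01 log units; that floor lies within the scatter) in this assay. Nothing else in the structure moves, so this step isolates that one stereocentre: the fact that compounds 1 and 3 differ only in the configuration as drawn. It gives only a floor, and its true size stays unfixed, since one end of the comparison is a limit and not a number: the limit of > 100000 nM in this assay, at which 1 of the 3 values shown sits.

From the compounds shown here alone, whether the same inversion would count for more on the longer fluorinated chain of compound 2, or how the other stereocentres of the shared core behave, stays open. So does the effect of a carboxylic acid or an amine in place of the terminal perfluoroalkyl part of the chain.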